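The compounds below may be only part of what the source reports. "The series", "measured", "known", "first", "only" and "open" are said of these compounds alone.

Compounds measured in a functional assay on A2780 cells (Homo sapiens) for antiproliferative activity, read by fluorescence, with a stated time of 72 h (a higher number here means a weaker inhibitor, a lower number a stronger inhibitor), so far:

Compound 1, `CN1CCC(C(=O)N2Cc3c(NC(=O)C4CCC4)n[nH]c3C2(C)C)CC1`: 140 nM
Compound 2, `CN1CCC(C(=O)N2Cc3c(NC(=O)c4ccsc4)n[nH]c3C2(C)C)CC1`: 140 nM
Compound 3, `CCCNC(=O)Nc1n[nH]c2c1CN(C(=O)C1CCN(C)CC1)C2(C)C`: 650 nM

Compound 3 gives the highest number of the three in this assay; compounds 1 and 2 both sit lower, each by the same step, a 4.6-fold higher number from compound 1 to compound 3 (0.67 log units; beyond the scatter) and a 4.6-fold higher number from compound 2 to compound 3 (0.67 log units; beyond the scatter), while no change at the digits printed from compound 1 to compound 2 (within the scatter).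

Compound 4, `CN1CCC(C(=O)N2Cc3c(NC(=O)c4cccs4)n[nH]c3C2(C)C)CC1`, differs from compound 3 as follows: thiophen-2-yl in place of propylamino on a carbonyl carbon. Among the compounds with values here, the steps that bear on this are those from compound 1 and compound 2 to compound 3, each modest and beyond the scatter, and the step from compound 1 to compound 2, which shows no change. Since a thiophen-3-yl on the carbonyl carbon matched the cyclobutyl of compound 1, a thiophen-2-yl is expected to behave similarly, so the number for compound 4 is expected to fall by about a 4.3-fold lower number from compound 3 to compound 4 (0.64 log units; beyond the scatter) relative to compound 3. Compound 4 is therefore estimated at 150 nM, within 60 nM to 400 nM.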

Compound 4, half-maximal inhibitory concentration: 30 nM
Compound 4: the middle estimate sits 5.0-fold (0.70 log units) above what was measured, outside the stated range (below it).
By their numbers in this assay, from the lowest: compound 4; then compounds 1 and 2 (each within the scatter of the next); then compound 3.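

Placing thiophen-2-yl instead of thiophen-3-yl on the carbonyl carbon gives a 4.7-fold lower number from compound 2 to compound 4 (0.67 log units; beyond the scatter), so the two thiophene attachments are not interchangeable here, which the earlier compounds could not show. Thiophen-2-yl also stands apart from cyclobutyl, with a 4.7-fold lower number from compound 1 to compound 4 (0.67 log units; beyond the scatter), and from propylamino, with a 22-fold lower number from compound 3 to compound 4 (1.34 log units; beyond the scatter), the largest step among these compounds. No evidence at hand explains these steps. On these data alone, whether a furan ring, a thiazole ring or a thiophen-2-yl ring carrying a methyl group or a chlorine would keep this gain remains open.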